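This account rests on a few compounds, and the source may have more. Where it says the series, first, only, none or still open, it means among the compounds named here.

Compound 1 `COc1cc(OC)c(Cl)c(-c2ccc3c(NC(=O)c4ccc(N5CCN(C)CC5)cc4)n[nH]c3n2)c1Cl`: 1.7 nM
Compound 2 `COc1cc(OC)c(Cl)c(-c2ccc3c(NC(=O)c4ccc(N5CCCCC5)cc4)n[nH]c3n2)c1Cl`: 558 nM
Compound 3 `COc1cc(OC)c(Cl)c(-c2ccc3c(NC(=O)c4ccc(N5CCN(C6CCC6)CC5)cc4)n[nH]c3n2)c1Cl`: 2.3 nM

All three values come from a functional assay on NCI-H1581 cells (Homo sapiens) for antiproliferative activity, read by CCK-8 assay, with a stated time of 72 h; a lower number here means a stronger inhibitor, a higher number a weaker inhibitor. Compound 3 gives 2.3 nM, the second highest of the three numbers, though it sits within the scatter of compound 1: a 1.4-fold higher number from compound 1 to compound 3 (0.13 log units; within the scatter). It lies far from compound 2: a 240-fold lower number from compound 2 to compound 3 (2.38 log units; beyond the scatter).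

The next compound is compound 4 `COc1cc(OC)c(Cl)c(-c2ccc3c(NC(=O)c4ccccc4)n[nH]c3n2)c1Cl`, with hydrogen in place of 4-cyclobutylpiperazin-1-yl on an aromatic carbon.

Among the compounds with values here, two steps bear most directly on this change. Exchanging the piperazine substituent left the number within the scatter, as the step to compound 3 shows, whereas losing the piperazine was costly: a 330-fold higher number from compound 1 to compound 2 (2.52 log units; beyond the scatter). Among these three compounds, both piperazines sit low and the piperidine sits high, and none goes against this. Within the data shown here, no measured compound yet carries hydrogen at this place, so the size of the step is uncertain. A large rise of similar size is expected: a 350-fold higher number from compound 3 to compound 4 (2.54 log units; beyond the scatter).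

For compound 4 the estimated value is 800 nM, with an expected range of 150 nM to 4000 nM.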

Compound 4, half-maximal inhibitory concentration: > 1000 nM
Compound 4 gave a limit, no number; the forecaster's own chance of this, stated with the estimate: 15%; middle value at least 1.2-fold (0.09 log units) from the limit.
By their numbers in this assay, from the lowest: compounds 1 and 3 (each within the scatter of the next); then compound 2. At a limit, above all of these: compound 4.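

In this assay compound 4 stands only as a limit, not as a number: the limit of > 1000 nM in this assay, at which 1 of the 4 values shown sits. Hydrogen in place of either piperazine is a large loss, an at least 430-fold higher number from compound 3 to compound 4 (2.63 log units; beyond the scatter) and an at least 580-fold higher number from compound 1 to compound 4 (2.76 log units; beyond the scatter), so the activity seen with the piperazines does not survive with the group removed altogether. Against the piperidine the floor of the step stays within the scatter, an at least 1.7-fold higher number from compound 2 to compound 4 (0.25 log units; that floor lies within the scatter), so these data do not show that piperidin-1-yl keeps anything over hydrogen at this place.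

As far as these compounds go, it remains open whether a morpholine ring, an unsubstituted piperazine or an open-chain dimethylamino group on this aromatic carbon would sit with compound 1 and compound 3 or with compound 2. From the compounds shown here alone, how far compound 4 lies past its limit is also unknown, so the true size of all three steps stays open.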